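Hydrazone Variation on a Shared Core Against an Enzyme Target

The compounds below may be only part of what the source reports. "The series", "measured", "known", "first", "only" and "open" are said of these compounds alone.

Measured compounds:
compound 1 `CC(C)=NNc1nc2ccccc2s1`: 30%
compound 2 `N#CCCN(N)c1nc2ccccc2s1`: 2%

In an assay for inhibition of Indoleamine 2,3-dioxygenase 1 (Homo sapiens), with a stated time of 1 h, tested at 0.1 mM (on this read-out higher numbers stand for more inhibition at the one concentration tested (going by the name of the read-out) and lower numbers for less inhibition), compound 1 gives 30%, the highest of the two numbers, with compound 2 at 2%, a gap beyond the scatter. Compound 3 `O=C(O)/C=N/Nc1nc2ccccc2s1` is not yet measured in this assay. It differs from compound 1 by a group of 5 heavy atoms (2 carbon, 1 nitrogen, 2 oxygen; no ring) in place of a group of 4 heavy atoms (3 carbon, 1 nitrogen; no ring), on a nitrogen on an aromatic ring. Among the compounds with values here, with no comparable step measured, the expectation is modest: compound 3 is estimated to fall somewhat below compound 1, with a change a number 10 percentage points lower from compound 1 to compound 3 (within the scatter) in this assay that may lie within the scatter. Compound 3 is expected to give 20%, in a range from 0% to 50%.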

Compound 3, a percentage reported as inhibition, at one concentration (the size of the read-out at that concentration, not a potency): 13%
The estimate for compound 3 lay 7 percentage points above the measured number; the measured number falls inside the stated range.
By their numbers in this assay, from the lowest: compound 2; then compound 3; then compound 1.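

In this assay, replacing the group of 4 heavy atoms on the nitrogen on an aromatic ring with the group of 5 heavy atoms gives a number 17 percentage points lower from compound 1 to compound 3 (beyond the scatter). Within the data shown here, this is the first step read at this position, and it shows that the read-out responds to a change made there. The entering group carries 1 hydrogen-bond donor and 2 hydrogen-bond acceptors, but no measurement at hand bears on what lies behind the step.

The compounds shown leave open how an ester or an amide would read in this place. They also leave open whether a longer chain would read differently.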